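A methoxy group added to the phenyl ring of compound 2

The source may hold more compounds than are shown below. What is called first, only, known or untested is meant among the compounds shown, and "the series" means these compounds.

Three compounds have been measured in a functional assay on the whole organism for inhibition, with Rattus norvegicus as the target, read by paw edema, at a dose of 50 mg/kg; a higher number here means more inhibition at the dose given (going by the name of the read-out), a lower number less inhibition:
Compound 1, `O=c1oc2cccnc2n1CN1CCN(c2cccc(C(F)(F)F)c2)CC1`, gives 25%.
Compound 2, `O=c1oc2cccnc2n1CN1CCN(c2ccccc2)CC1`, gives 11%.
Compound 3, `O=c1oc2cccnc2n1CCCN1CCN(c2ccccc2)CC1`, gives 16%.

Compound 2 stands lowest of the three numbers. Its nearest neighbour is compound 3, whose number lies within the scatter of that of compound 2, so no order can be drawn between them. Compound 1 lies beyond the scatter above compound 2. Going by the values given here, the only measured step between compounds that differ in one place is a number 14 percentage points lower from compound 1 to compound 2 (beyond the scatter), a modest change.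

Compound 4, `COc1ccccc1N1CCN(Cn2c(=O)oc3cccnc32)CC1`, is not yet measured. It differs from compound 2 by methoxy in place of hydrogen on an aromatic carbon. Among the compounds with values here, the single step that bears on this change is a number 14 percentage points lower from compound 1 to compound 2 (beyond the scatter), since it also concerns a substituent on the same six-membered ring of carbon only; it was modest. A different group at a different place gives no firm direction, so in this assay a small step is expected, possibly a rise, but not clearly beyond the scatter. Compound 4 is therefore estimated at 20%, with a range from 5% to 38%. This estimate means an expected step of a number 9 percentage points higher from compound 2 to compound 4 (within the scatter).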

Compound 4, a percentage reported as inhibition, in the whole organism at one dose (the size of the read-out at that dose, not a potency): 15%
For compound 4 the middle estimate is 5 percentage points above the measured one; the measured number falls inside the stated range.
By their numbers in this assay, from the lowest: compounds 2, 4, 3 and 1 (each within the scatter of the next, the first and the last beyond it).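

In this assay, methoxy in place of hydrogen on an aromatic carbon, ortho to a large group, gives a number 4 percentage points higher from compound 2 to compound 4 (within the scatter), so no change can be read from this replacement. Going by these compounds alone, this is the first substituent tested at this place, and it shows that, in the phenyl to 2-methoxyphenyl change, adding one hydrogen-bond acceptor and 2 heavy atoms leaves the number within the scatter, unlike the step beyond the scatter seen with trifluoromethyl in a number 14 percentage points lower from compound 1 to compound 2 (beyond the scatter). No measurement offered here accounts for this result.

The compounds shown leave open whether a hydroxyl group or a chlorine atom at this same place would move the number beyond the scatter. They also leave open whether methoxy would read differently on another carbon of the ring, or with the longer chain of compound 3.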